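Acetyl on the azetidine amine nitrogen of compound 2

The source may hold more compounds than are shown below. What is called first, only, known or untested is meant among the compounds shown, and "the series" means these compounds.

Compound 1 `COc1cc2c(cc1NS(=O)(=O)c1cccc(Cl)c1Cl)[nH]c(=O)n2CCN(C)C` gives 2000 nM in a functional assay on CHO cells for antagonist activity at C-C chemokine receptor type 4 (Homo sapiens), read by radioligand binding and GTPgammaS binding; a higher number here means a weaker inhibitor, a lower number a stronger inhibitor. Among the compounds with values here, compound 2 `COc1cc2c(cc1NS(=O)(=O)c1cccc(Cl)c1Cl)[nH]c(=O)n2C1CNC1` gives 398 nM in this assay, the lower of the two measured numbers; the single measured step, a 5.0-fold lower number from compound 1 to compound 2 (0.70 log units; beyond the scatter), sets it apart. Compound 3 `COc1cc2c(cc1NS(=O)(=O)c1cccc(Cl)c1Cl)[nH]c(=O)n2C1CN(C(C)=O)C1` carries acetyl in place of hydrogen on an amine nitrogen in a ring. Within the data shown here, no measured step touches the amine nitrogen in the ring, so the step of a 5.0-fold lower number from compound 1 to compound 2 (0.70 log units; beyond the scatter) bears on it only loosely, showing that the group on the aromatic nitrogen matters. For compound 3 the estimated step is a 2.0-fold higher number from compound 2 to compound 3 (0.30 log units; within the scatter), a modest rise. The estimate for compound 3 is 800 nM, ranging from 200 nM to 4000 nM.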

Compound 3, half-maximal inhibitory concentration in the C-C chemokine receptor type 4 assay: 200 nM
The estimate for compound 3 lay 4.0-fold (0.60 log units) above the measured number; low and high end bracket the measured number.
By their numbers in the C-C chemokine receptor type 4 assay, from the lowest: compounds 3 and 2 (each within the scatter of the next); then compound 1.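

On the amine nitrogen of the azetidine, acetyl is tolerated in the C-C chemokine receptor type 4 assay, with a 2.0-fold lower number from compound 2 to compound 3 (0.30 log units; within the scatter), so the hydrogen on this nitrogen is not required for this read-out. The 1-acetylazetidin-3-yl group also stays clearly ahead of 2-(dimethylamino)ethyl on the aromatic nitrogen, with a 10-fold lower number from compound 1 to compound 3 (1.00 log units; beyond the scatter). In a physicochemical assay for solubility, read by chemiluminescence, measured as kinetic solubility (on this read-out higher numbers stand for higher solubility and lower numbers for lower solubility), compound 2 gives 194 ug/mL and compound 3 gives 8 ug/mL on this read-out. The same acetyl is far from neutral in the physicochemical assay, where it carries a clear cost: the measured solubility of compound 2, 194 ug/mL, and of compound 3, 8 ug/mL, a 24-fold lower number (1.38 log units; beyond the scatter)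

Still open, as far as these compounds go, is whether a methyl or a methanesulfonyl group on this amine nitrogen would hold the number in the C-C chemokine receptor type 4 assay without the drop seen in the physicochemical assay.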